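This account rests on a few compounds, and the source may have more. Where it says the series, first, only, none or still open, it means among the compounds named here.

Measured in a functional assay on A20 cells (Mus musculus) for inhibition, with stated times of 1 h, 16 h and 24 h; on this read-out higher numbers stand for weaker inhibition and lower numbers for stronger inhibition:
- compound 1 `N#CC1(NC(=O)[C@@H]2C[C@@H](S(=O)(=O)c3ccccc3)C[C@H]2C(=O)N2CCOCC2)CCC1`: 236 nM
- compound 2 `C[C@@H]1CN(C(=O)[C@@H]2C[C@H](S(=O)(=O)c3ccccc3)C[C@H]2C(=O)NC2(C#N)CC2)C[C@H](C)O1`: 1 nM

Not yet measured: compound 3 `CN1CCN(C(=O)[C@@H]2C[C@H](S(=O)(=O)c3ccccc3)C[C@H]2C(=O)NC2(C#N)CC2)CC1`.

Compound 2 holds the lower of the two numbers, 1 nM, and the gap to compound 1 at 236 nM lies well beyond the scatter. Compound 3 carries 4-methylpiperazin-1-yl in place of 2,6-dimethylmorpholin-4-yl on a carbonyl carbon. Going by the values given here, no measured pair differing in one place is available to calibrate this change. A modest move towards a higher number in this assay is expected, with an estimated step of a 4.0-fold higher number from compound 2 to compound 3 (0.60 log units; beyond the scatter). Compound 3 is expected at 4 nM, with an estimated range of 1 nM to 20 nM.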

Compound 3, half-maximal inhibitory concentration: 17 nM
The estimate for compound 3 lay 4.3-fold (0.63 log units) below the measured number; the range from low to high includes it.
By their numbers in this assay, from the lowest: compound 2; then compound 3; then compound 1.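

Working across one place, a 17-fold higher number from compound 2 to compound 3 (1.23 log units; beyond the scatter) in this assay gives the series its first direct comparison and shows weaker inhibition with 4-methylpiperazin-1-yl on a carbonyl carbon. This position therefore distinguishes between two six-membered non-aromatic rings, each with 2 hetero atoms and no net charge. No measurement at hand explains the step.

The change swaps the ring atom and the methyl pattern together, leaving their separate contributions unresolved. Unsubstituted morpholin-4-yl or piperazin-1-yl at this position, on the core of compound 2, remains an open comparison.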